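Ethyl for Isopropoxy on a Weakly Cytotoxic Series

The compounds below may be only part of what the source reports. "The series", "measured", "known", "first", "only" and "open" are said of these compounds alone.

compound 1 `CCOc1ccc(N2C(=O)[C@@]3(NC2=S)C(c2ccc(Cl)cc2)CN(C)[C@]32C(=O)Nc3ccccc32)cc1`: 81700 nM
compound 2 `CC(C)Oc1ccc(C2CN(C)[C@]3(C(=O)Nc4ccccc43)[C@]23NC(=S)N(c2ccc(F)c(Cl)c2)C3=O)cc1`: "not active" (no number reported)
compound 3 `CCOc1ccc(N2C(=O)[C@@]3(NC2=S)C(c2ccc(Cl)cc2)CN(C)[C@]32C(=O)Nc3ccc(Br)cc32)cc1`: "not active" (no number reported)

In a functional assay on SiHa cells (Homo sapiens) for cytotoxicity, read by MTT assay, with a stated time of 48 h (a lower number here means a stronger inhibitor, a higher number a weaker inhibitor), compound 1 gives 81700 nM, the only numbered result in the set. Compound 2 returns "not active" (no number reported), with no single number reported. Compound 3 likewise returns "not active" (no number reported). Compound 2 therefore stands alongside compound 3 among the entries without a figure, while compound 1 alone carries a value.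

Compound 4 `CCc1ccc(C2CN(C)[C@]3(C(=O)Nc4ccccc43)[C@]23NC(=S)N(c2ccc(F)c(Cl)c2)C3=O)cc1` differs from compound 2 by ethyl in place of isopropoxy on an aromatic carbon. Going by the values given here, no step between measured compounds exists to anchor this change, so in this assay the expectation is for no shift beyond the usual scatter, and compound 4 is expected to stay weak. Compound 4 is estimated at 100000 nM, within a range from 40000 nM to 300000 nM, because compound 2 gives "not active" (no number reported).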

Compound 4, half-maximal inhibitory concentration: 42500 nM
Estimate against measurement, compound 4: 2.4-fold (0.37 log units) above; measured number inside the range.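

No step can be read between compound 2 and compound 4: compound 2 carries no number. The compounds shown leave open what replacing 4-isopropoxyphenyl with 4-ethylphenyl does to cytotoxicity. No measured evidence bears on this result.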